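The source may report more compounds than this note shows. Statements on the series, on what has been measured and on what is new or still open speak of the compounds shown alone.

Measured compounds:
compound 1 `CC(C)Cn1cc(-c2ccnc3[nH]c(C4CCN(CC(=O)N(C)C)CC4)cc23)ccc1=O` — 6.6 uL/min
compound 2 `CC(C)n1cc(-c2ccnc3[nH]c(C4CCN(Cc5cccs5)CC4)cc23)ccc1=O` — 43 uL/min

Of the compounds shown here, two have been measured in an ADME assay on cells (Hepatocyte, Rattus norvegicus) for metabolic stability; a higher number here means faster removal of the compound, a lower number slower removal. Compound 1 gives 6.6 uL/min, the lower of the two numbers. Compound 2 gives 43 uL/min, a number beyond the usual scatter from that of compound 1; since the two compounds differ in more than one place, their values simply stand side by side without a single change to connect them. Compound 3 `CN(C)C(=O)CN1CCC(c2cc3c(-c4ccc(=O)n(C5CCOCC5)c4)ccnc3[nH]2)CC1` has not yet been measured. It is derived from compound 1 by one change: oxan-4-yl in place of isobutyl on an aromatic nitrogen. The change sits on an aromatic nitrogen of the shared core, where the isobutyl of compound 1 is exchanged for oxan-4-yl. Within the data shown here, with no measured pair of this kind to draw on, the expectation rests on compound 1 alone, whose 6.6 uL/min sets the starting point. Compound 3 is expected to stay close to that value, with a step of a 1.1-fold lower number from compound 1 to compound 3 (0.04 log units; within the scatter) that is not expected to go beyond the scatter in either direction. The estimate for compound 3 is 6 uL/min, with a range from 2.5 uL/min to 15 uL/min.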

Compound 3, intrinsic clearance in a liver preparation (reported as CLH), per the amount of preparation that the assay uses: 2.3 uL/min
Compound 3: middle estimate off by 2.6-fold (0.42 log units), on the high side, outside the stated range (below it).
By their numbers in this assay, from the lowest: compound 3; then compound 1; then compound 2.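

Among these compounds, this is the first change at the aromatic nitrogen of the shared core that can be read on its own: in this assay, oxan-4-yl in place of isobutyl gives a 2.9-fold lower number from compound 1 to compound 3 (0.46 log units; beyond the scatter) with the rest of the structure unchanged. The position therefore affects this read-out, and the exchange, which brings in a six-membered non-aromatic ring and a hydrogen-bond acceptor absent from isobutyl, moves the number beyond the scatter towards slower removal. No measurement shown here explains the step, so it stands as an observation only.

This single step cannot separate the contribution of the ring from that of its oxygen, a question that a cyclohexyl group or an open methoxyethyl chain on the same nitrogen would address. On these data alone, compound 2 differs from compound 1 and compound 3 in more than one place, so it also remains open whether the same exchange would give a similar step in a compound carrying the other side chain of compound 2.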